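The compounds below may be only part of what the source reports. "The series", "measured", "known", "first", "only" and "open" are said of these compounds alone.

Compound 1 `CCc1ccc(NC2=CC(=O)c3c(nc4n3[C@H]3OC[C@@H](O)[C@H]3OC4)C2=O)cc1`: > 4000 nM
Compound 2 `O=C1C=C(Nc2ccc(I)cc2)C(=O)c2c1nc1n2[C@H]2OC[C@@H](O)[C@H]2OC1`: 2300 nM

In a functional assay on ECa-109 cells for inhibition, with ECa-109 cell line (Homo sapiens) as the target, read by sulforhodamine B assay (a higher number here means a weaker inhibitor, a lower number a stronger inhibitor), compound 1 returns only > 4000 nM, which is a limit of the assay rather than a number. Compound 1 thus stands at the limit of > 4000 nM in this assay, at which 1 of the 2 values shown sits. Compound 2 gives 2300 nM in this assay. Compound 3 `O=C1C(Nc2cccc(F)c2)=CC(=O)c2c1nc1n2[C@H]2OC[C@@H](O)[C@H]2OC1` differs from compound 1 by 3-fluorophenyl in place of 4-ethylphenyl on an amine nitrogen. Within the data shown here, no measured step of this kind exists, so the expected step is an at least 1.3-fold lower number from compound 1 to compound 3 (0.12 log units; that floor lies within the scatter), a small move toward a stronger inhibitor that may well stay within the scatter or end at a limit again. Compound 3 is estimated at 3000 nM, with a range from 1200 nM to 9000 nM.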

Compound 3, half-maximal inhibitory concentration: 2370 nM
Compound 3: the middle estimate sits 1.3-fold (0.10 log units) above what was measured; low and high end bracket the measured number.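

In this assay, 3-fluorophenyl in place of 4-ethylphenyl on the amine nitrogen gives an at least 1.6-fold lower number from compound 1 to compound 3 (0.22 log units; that floor lies within the scatter), so this position can carry a group that returns a measured number. Compound 1 gives > 4000 nM, which is a limit and not a number. The step is therefore only a floor, and its true size cannot be read: the limit of > 4000 nM in this assay, at which 1 of the 3 values shown sits.

The compounds shown leave open whether the fluorine or the loss of the ethyl group matters more. They also leave open how a plain phenyl or a methoxyphenyl on this nitrogen would read.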